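The source may hold more compounds than are shown below. What is called first, only, known or untested is meant among the compounds shown, and "the series" means these compounds.

Among the compounds with values here, in an ADME assay on microsomes from liver (Mus musculus) for metabolic stability (on this read-out lower numbers stand for a shorter-lived compound and higher numbers for a longer-lived compound), compound 1 `NS(=O)(=O)CC(=O)NCCSc1nonc1/C(=N/O)Nc1cccc(C(F)F)c1` gives 1.5 h, the highest of the three numbers so far. Compound 3 `C[C@H](CSc1nonc1/C(=N/O)Nc1ccc(F)c(Br)c1)NC(=O)CS(N)(=O)=O` gives 0.537 h and compound 2 `CC1(C(=O)NCCSc2nonc2/C(=N/O)Nc2ccc(F)c(C(F)F)c2)CCN1` gives 0.268 h, both lower than compound 1 by more than the usual scatter. Within the data shown here, no measured pair differs in only one place, so these gaps cannot be assigned to any single change.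

Compound 4 `N#Cc1cccc(N/C(=N\O)c2nonc2SCCNC(=O)CS(N)(=O)=O)c1` has not yet been measured in this assay. It differs from compound 1 in one place: cyano in place of difluoromethyl on an aromatic carbon. Read one bond further out, this turns 3-(difluoromethyl)phenyl into 3-cyanophenyl.

Among the measured compounds shown here, with no measured step for this change, no shift beyond the scatter is expected in this assay, and the expectation is anchored on compound 1 at 1.5 h. The expected change is small, a 1.3-fold lower number from compound 1 to compound 4 (0.10 log units; within the scatter). The low end of the range allows for a drop like that of compound 3 at 0.537 h. The estimate for compound 4 is 1.2 h, with an expected range of 0.5 h to 2.8 h.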

Compound 4, half-life: > 3 h
Compound 4: a limit, no number; the forecaster's own chance of this, stated with the estimate: 3%; middle value at least 2.5-fold (0.39 log units) from the limit.
By their numbers in this assay, from the lowest: compounds 2 and 3 (each within the scatter of the next); then compound 1. At a limit, above all of these: compound 4.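

Compound 4 gives > 3 h in this assay, which is a limit of the assay and not a number. Cyano in place of difluoromethyl on an aromatic carbon gives an at least 2.0-fold higher number from compound 1 to compound 4 (0.30 log units; that floor lies within the scatter), the first single-place step in the series. At this place, meta to a large group, the change does not shorten the half-life, but its full size stays unresolved, with one compound at the top of the read-out: the limit of > 3 h in this assay, at which 1 of the 4 values shown sits.

Going by these compounds, how a trifluoromethyl, a methoxy or a carboxylic acid on the same aromatic carbon would read remains open. On these data alone, whether the same change carries over to the side chains of compound 2 and compound 3 is also open.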